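The compounds below may be only part of what the source reports. "The series", "measured", "known", "first", "only" and "open" are said of these compounds alone.

Within the data shown here, compound 1 `Cc1cc(C(=O)O)ccc1CN1CCC[C@H](O[C@H](CO)c2ccccc2)[C@@H]1c1ccccc1` is one of three compounds measured in an assay on isolated protein for activation of cGMP-dependent protein kinase 1 (Homo sapiens), read by ADP-Glo, with stated times of 30 min and 2 h, in the presence of a further agent that is not named here; on this read-out lower numbers stand for an effect already at smaller amounts and higher numbers for an effect only at larger amounts of compound; compound 1 gives 25000 nM, compound 2 `OC[C@@H](O[C@H]1CCCN(Cc2ncc[nH]2)[C@H]1c1ccccc1)c1cc(Cl)cc(Cl)c1` gives 47000 nM, and compound 3 `Cc1nc(C(=O)O)ccc1CN1CCC[C@H](O[C@H](CO)c2cc(Cl)cc(Cl)c2)[C@@H]1c1ccccc1` gives 370 nM. The values of compound 1 and compound 2 lie within the scatter of each other. Compound 4 `Cc1cc(C(=O)O)ccc1CN1CCC[C@H](O[C@H](CO)c2cc(Cl)nc(Cl)c2)[C@@H]1c1ccccc1` differs from compound 1 by 2,6-dichloropyridin-4-yl in place of phenyl on a saturated chain carbon bound to an oxygen on a saturated carbon and a saturated chain carbon. Among the measured compounds shown here, no measured step changes this ring alone. For the measured compounds named here, the only measured step, a 130-fold lower number from compound 2 to compound 3 (2.10 log units; beyond the scatter), concerns the group on the ring nitrogen, both partners carrying the dichlorophenyl ring, so it does not bear directly on this change. Compounds 1 and 3 differ in two places at once, so their values give only a hint. For compound 4 a moderate step toward a smaller number is expected, an 8.3-fold lower number from compound 1 to compound 4 (0.92 log units; beyond the scatter), with the estimate 3000 nM in a range from 500 nM to 15000 nM.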

Compound 4, half-maximal effective concentration: 2400 nM
Compound 4: middle estimate off by 1.3-fold (0.10 log units), on the high side; the measured number falls inside the stated range.
By their numbers in this assay, from the lowest: compound 3; then compound 4; then compounds 1 and 2 (each within the scatter of the next).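

Setting 2,6-dichloropyridin-4-yl in place of phenyl on the saturated chain carbon bound to an oxygen on a saturated carbon and a saturated chain carbon gives a large change (a 10-fold lower number from compound 1 to compound 4 (1.02 log units; beyond the scatter)). Among these compounds, this is the first step read for this ring alone, with the rest of compound 1 unchanged, and it shows that this place strongly affects the number. No available finding accounts for the size of this step.

The compounds shown leave open how the step divides between the ring nitrogen and the two chlorine atoms. A plain pyridin-4-yl group or a phenyl ring bearing two chlorine atoms on the core of compound 1 would separate the two.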